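Compound 4: A Change No Measured Step Has Touched

The source may hold more compounds than are shown below. What is called first, only, known or untested is meant among the compounds shown, and "the series" means these compounds.

In a functional assay on CNE-2 cells (Homo sapiens) for antiproliferative activity, read by sulforhodamine B assay, with a stated time of 48 h (on this read-out higher numbers stand for weaker inhibition and lower numbers for stronger inhibition), compound 1 `COc1ccc(/C=C/C(=O)c2ccccc2-c2ccc(OC)c(OC)c2)cc1` gives 320 nM. Compound 2 `COc1ccc(/C=C/C(=O)c2ccccc2-c2ccc(OC)c(OC)c2)cc1OC` gives 2500 nM, and compound 3 `COc1ccc(OC)c(/C=C/C(=O)c2ccccc2-c2ccc(OC)c(OC)c2)c1` gives 2400 nM. Compound 2 thus shares the high end of these numbers with compound 3, the gap being a 1.0-fold lower number from compound 2 to compound 3 (0.02 log units; within the scatter). Compound 1 stands clearly lower than both, with steps of a 7.8-fold higher number from compound 1 to compound 2 (0.89 log units; beyond the scatter) and a 7.5-fold higher number from compound 1 to compound 3 (0.88 log units; beyond the scatter).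

In compound 4 `COc1ccc(/C=C/C(=O)c2ccccc2-c2ccc(F)cc2)cc1OC`, a 4-fluorophenyl stands in place of 3,4-dimethoxyphenyl on an aromatic carbon, ortho to a large group: 4-fluorophenyl in place of 3,4-dimethoxyphenyl on an aromatic carbon. All three measured steps alter the group on the double-bonded chain, and none touches this aromatic carbon, so they bear on the new change only indirectly. They show that one change elsewhere in this small series can be modest in size, as with a 7.5-fold higher number from compound 1 to compound 3 (0.88 log units; beyond the scatter), or can leave the number within the scatter, as with a 1.0-fold lower number from compound 2 to compound 3 (0.02 log units; within the scatter). The data give no direction for the new change, so the expectation stays close to compound 2, with an estimated 1.2-fold higher number from compound 2 to compound 4 (0.08 log units; within the scatter). Compound 4 is expected at 3000 nM, with an estimated range of 800 nM to 11000 nM.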

Compound 4, half-maximal inhibitory concentration: 81 nM
For compound 4 the middle estimate is 37-fold (1.57 log units) above the measured one, outside the stated range (below it).
By their numbers in this assay, from the lowest: compound 4; then compound 1; then compounds 3 and 2 (each within the scatter of the next).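

In this assay, a 31-fold lower number from compound 2 to compound 4 (1.49 log units; beyond the scatter) is the first step shown at this aromatic carbon, ortho to a large group, and it is large, whereas the steps among compounds 1, 2 and 3 are modest or within the scatter. Compounds 1, 2 and 3 all keep 3,4-dimethoxyphenyl here, so only compound 4 shows that the group at this carbon can move the number substantially, and that 4-fluorophenyl in place of 3,4-dimethoxyphenyl gives stronger inhibition when the rest of compound 2 stays the same. Nothing available here accounts for the size of this step.

Since the step removes both methoxy groups and brings in fluorine at once, the compounds shown leave open how much of the change belongs to each part, and a plain phenyl, a 4-chlorophenyl or a 4-aminophenyl at this carbon would help to separate them. They also leave open whether 4-fluorophenyl would have a step of similar size alongside the 4-methoxyphenyl of compound 1 or the 2,5-dimethoxyphenyl of compound 3.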